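The source may hold more compounds than are shown below. What is called first, only, known or untested is meant among the compounds shown, and "the series" means these compounds.

Notes on cytotoxicity in the series. Compound 1 `CCCCNC(=O)Nc1cc2nc(C3CCCCC3)[nH]c2cc1N(CC)CC` gives in an ADME assay on Vero cells (Chlorocebus sabaeus) for cytotoxicity, read by resazurin assay, with a stated time of 3 days (a higher number here means a weaker inhibitor, a lower number a stronger inhibitor), a value of > 100 ug/mL, which is a limit of the assay and not a number. Compound 2 `O=C(Nc1cc2nc(C3CCCCC3)[nH]c2cc1N1CCCC1)c1ccc(Br)cc1` likewise sits at a limit of > 100 ug/mL in this assay. Compound 3 `CN(C)c1cc2[nH]c(C3CCCCC3)nc2cc1NC(=O)c1cccs1` also reads > 100 ug/mL in this assay, again a limit. Where compound 1 stands is therefore known only as the limit of > 100 ug/mL in this assay, at which 3 of the 3 values shown sit. Compound 4 `CCN(CC)c1cc2[nH]c(C3CCCCC3)nc2cc1NC(=O)NCc1ccccc1` differs from compound 1 by phenyl in place of propyl on a saturated chain carbon bound to an amide-type nitrogen. Within the data shown here, with every measured value at the same limit, no step between measured compounds can be sized. The step of a number no higher from compound 1 to compound 4 (the limit leaves the size open) is expected to stay within the scatter, in no clear direction. Compound 4 is accordingly expected to give 100 ug/mL, with a range of 40 ug/mL to 300 ug/mL, most probably again only a limit.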

Compound 4, half-maximal inhibitory concentration: > 100 ug/mL
Compound 4 ended at the assay's limit; the forecaster's own chance of this, stated with the estimate: 80%; the middle value lies on the limit itself.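

No new step can be read: compound 1 and compound 4 both stand at a limit in this assay and the change from propyl to phenyl has no readable size. The compounds shown leave open at what concentration any member of the series becomes cytotoxic, since none gives a value inside the assay's range: the limit of > 100 ug/mL in this assay, at which 4 of the 4 values shown sit.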